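The compounds below may be only part of what the source reports. "The series", "measured", "known", "first", "only" and "open" are said of these compounds alone.

Measured compounds in an assay on HEK293 cells for inhibition of Voltage-dependent T-type calcium channel subunit alpha-1G (Homo sapiens), read by patch clamp; a lower number here means a stronger inhibitor, a higher number a weaker inhibitor:

compound 1 `CCCc1nc(-c2ccccc2)c(CNCCN2CCN(c3ccccc3Cl)CC2)o1` — 4370 nM
compound 2 `CCCc1nc(-c2ccccc2)c(CNCCCN2CCN(c3cccc(Cl)c3)CC2)o1` — 1750 nM
compound 3 `CCCc1nc(-c2ccccc2)c(CNCCCN2CCN(c3ccc(C(F)(F)F)cc3)CC2)o1` — 7250 nM

Compound 1 stands in the upper part of this small set. Its number and that of compound 3 lie within the usual scatter of each other, so no order between them can be read. Compound 2 gives a lower number, and that gap lies beyond the scatter. Among the measured compounds shown here, the only change among the measured compounds that alters just the aryl group on the ring nitrogen is a 4.1-fold higher number from compound 2 to compound 3 (0.62 log units; beyond the scatter), where the aryl group swaps 3-chlorophenyl for 4-(trifluoromethyl)phenyl; it is a modest step towards weaker inhibition.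

Compound 4 `CCCc1nc(-c2ccccc2)c(CNCCN2CCN(c3cccc(C)c3C)CC2)o1` has not yet been measured. It differs from compound 1 in one place: 2,3-dimethylphenyl in place of 2-chlorophenyl on an amine nitrogen in a ring. For the measured compounds named here, this is a different exchange on the same kind of position, and none of the measured steps covers a chlorine-for-methyl swap or a 2,3-dimethyl pattern. Going by the values given here, the one step that does bear on it, from compound 2 to compound 3, was modest, so a change of similar or smaller size is expected, in either direction or none beyond the scatter. On that basis compound 4 is estimated at 3800 nM, with a range from 1200 nM to 12000 nM, which means an expected step of a 1.2-fold lower number from compound 1 to compound 4 (0.06 log units; within the scatter).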

Compound 4, half-maximal inhibitory concentration: 1710 nM
Beside the measured number, compound 4's estimate is 2.2-fold (0.35 log units) above it; measured number inside the range.
By their numbers in this assay, from the lowest: compounds 4 and 2 (each within the scatter of the next); then compounds 1 and 3 (each within the scatter of the next).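

In this assay, placing 2,3-dimethylphenyl in place of 2-chlorophenyl on an amine nitrogen in a ring gives a 2.6-fold lower number from compound 1 to compound 4 (0.41 log units; beyond the scatter), a modest move towards stronger inhibition. Among the compounds shown here, the only earlier step at this kind of position went towards weaker inhibition, so the aryl group on this nitrogen can shift the number in either direction. The new step also shows that an aryl group made of carbon only, with no halogen on it, can give the stronger inhibition of this pair, although nothing measured here explains the change.

This single exchange removes a chlorine and adds two methyl groups at once, so the part played by each stays unresolved; a plain phenyl, 2-methylphenyl or 3-methylphenyl group on the same nitrogen would help to separate them. From the compounds shown here alone, it also remains open whether the 2,3-dimethylphenyl group would give a similar step on the longer chain of compound 2, and how an aryl group carrying a methoxy group would compare with these.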